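Spiro-triazole series: ortho-substituted aryl swap on the triazole

The source may hold more compounds than are shown below. What is called first, only, known or untested is meant among the compounds shown, and "the series" means these compounds.

The series shares one core, seen in compound 1 `CCOc1ccccc1-n1nncc1CN1C(=O)C2(C(C#N)=C(N)Oc3c2c2nc4ccccc4nc2c2ccccc32)c2ccccc21` and compound 2 `N#CC1=C(N)Oc2c(N)cc3nc4ccccc4nc3c2C12C(=O)N(Cc1cnnn1-c1ccccc1Cl)c1ccccc12`. In a functional assay on MCF7 cells (Homo sapiens) for antiproliferative activity, read by MTT assay, with a stated time of 48 h (a lower number here means a stronger inhibitor, a higher number a weaker inhibitor), compound 2 gives 34400 nM. Among the compounds with values here, that is the only number the set holds so far. For compound 1 this assay reports a limit rather than a number, > 50000 nM; note (the limit of > 50000 nM in this assay, at which 1 of the 2 values shown sits). Within the data shown here, no pair of measured compounds differs in a single place, so no measured step can be compared.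

Compound 3 `Cc1cc(C)c(-n2nncc2CN2C(=O)C3(C(C#N)=C(N)Oc4c(N)cc5nc6ccccc6nc5c43)c3ccccc32)c(C)c1` differs from compound 2 only at the aryl group on the triazole nitrogen: 2,4,6-trimethylphenyl in place of 2-chlorophenyl on an aromatic nitrogen. Nothing measured in the set speaks to a change of this kind. Compound 3 is expected to stay close to compound 2, with a step of a 1.0-fold higher number from compound 2 to compound 3 (0.02 log units; within the scatter) not clearly beyond the scatter in this assay. The estimate for compound 3 in this assay is 36000 nM, within a range from 12000 nM to 110000 nM.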

Compound 3, half-maximal inhibitory concentration: > 50000 nM
Compound 3 gave a limit, no number; the forecaster's own chance of this, stated with the estimate: 40%; middle value at least 1.3-fold (0.14 log units) away from the limit.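

In this assay compound 3 gives > 50000 nM, which is a limit of the assay and not a number. This gives the series its first step at the aryl group on the triazole nitrogen, an at least 1.4-fold higher number from compound 2 to compound 3 (0.16 log units; that floor lies within the scatter), so 2,4,6-trimethylphenyl in place of 2-chlorophenyl is not shown to differ beyond the scatter, and the upper end of the step stays unfixed. Any difference past the limit cannot be sized at this position, and the limit now holds more of the set than measured numbers do: the limit of > 50000 nM in this assay, at which 2 of the 3 values shown sit.

On these data alone, whether an unsubstituted phenyl, or an aryl group carrying an amine or a carboxylic acid, on this triazole nitrogen gives a number clearly under that of compound 2 stays open. Compound 1 differs from compound 2 in more than one place, so the compounds shown do not separate the aryl group from the rest of the core.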